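Swapping ethyl for iodo on the urea-linked ring

The source may report more compounds than this note shows. Statements on the series, on what has been measured and on what is new or still open speak of the compounds shown alone.

Measured so far:
Compound 1 `CCc1cccc(NC(=O)N[C@H](C)c2ccccc2)c1` gives 36% in an ADME assay on the whole organism with Oryza sativa as the target, tested at 10 uM; a higher number here means a weaker effect of the compound at the concentration tested, a lower number a stronger effect.
Compound 2 `CCc1cccc(NC(=O)N[C@@H](C)c2ccccc2)c1` gives 86%.
Compound 3 `CC(=O)c1ccc(NC(=O)N[C@H](C)c2ccccc2)cc1` gives 84%.

Compound 1 has the lowest number of the three, so its effect is the strongest shown. Within the data shown here, the one single-place step measured, a number 50 percentage points higher from compound 1 to compound 2 (beyond the scatter), is large, and it rests only on (the fact that compounds 1 and 2 differ only in the configuration as drawn). Among the measured compounds shown here, compound 3 and compound 1 differ in more than one place, so their values are simply two points with no step between them.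

Compound 4 `C[C@@H](NC(=O)Nc1cccc(I)c1)c1ccccc1` is compound 1 with iodo in place of ethyl on an aromatic carbon. For the measured compounds named here, no measured step concerns such a change, so there is no basis to expect a step beyond the scatter in this assay. Compound 4 is therefore estimated at 45% (range 20% to 75%), which is expected to mean a number 9 percentage points higher from compound 1 to compound 4 (within the scatter).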

Compound 4, a percentage reported as activity, at one concentration (the size of the read-out at that concentration, not a potency): 73%
Estimate against measurement, compound 4: 28 percentage points below; measured number inside the range.
By their numbers in this assay, from the lowest: compound 1; then compound 4; then compounds 3 and 2 (each within the scatter of the next).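

In this assay, iodo in place of ethyl on an aromatic carbon gives a number 37 percentage points higher from compound 1 to compound 4 (beyond the scatter) and so a weaker effect at the concentration tested. The earlier large step came from configuration alone, whereas this one shows that the group at this ring position also matters, with the rest of compound 1 unchanged. Nothing measured here explains why this swap produces a step of this size.

From the compounds shown here alone, it remains open whether a propyl chain or a methoxy group at this position would stay close to compound 1 or compound 4. A single swap also cannot show whether ethyl is unusually favourable here or iodo unusually unfavourable.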